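A few compounds are considered here, and "the series" means these few. Any claim that something is new, unique, unknown or untested is made for them only; others in the source may bear on it.

Measured compounds:
compound 1 `CC(C)Oc1cc(C/N=C(\S)NCc2ccc(C(C)(C)C)cc2)ccc1NS(C)(=O)=O` — 3600 nM
compound 2 `CC(C)(C)c1ccc(C/N=C(\S)NCc2ccc(NS(C)(=O)=O)cc2F)cc1` — 27.3 nM

The two measured compounds were tested in a functional assay on CHO cells for antagonist activity at transient receptor potential cation channel subfamily V member 1 (Rattus norvegicus); a higher number here means a weaker inhibitor, a lower number a stronger inhibitor. Compound 1 gives 3600 nM in this assay, while compound 2 gives 27.3 nM. Among the measured compounds shown here, of the two numbers, compound 2 stands lowest; its gap to compound 1 is well beyond the scatter of repeated measurements, and no single-point step between the two is recorded, so the account rests on what the two values show.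

The next compound, compound 3 `CC(C)(C)c1ccc(C/N=C(\S)NCc2ccc(NS(C)(=O)=O)cc2Cl)cc1`, keeps the core of compound 2 and changes one place: chloro in place of fluoro on an aromatic carbon. The position is an aromatic carbon of a six-membered aromatic ring of carbon only, ortho to a large group and meta to the methanesulfonamido group.

For the measured compounds named here, no measured step of this kind exists here, so the expectation has to be an open one. Compound 3 is expected to stay close to compound 2, with a step of a 1.5-fold higher number from compound 2 to compound 3 (0.17 log units; within the scatter) that need not go beyond the scatter in either direction. The estimate for compound 3 in this assay is 40 nM, within a range from 14 nM to 120 nM.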

Compound 3, inhibition constant: 45.5 nM
Compound 3: middle estimate off by 1.1-fold (0.06 log units), on the low side; the range from low to high includes it.
By their numbers in this assay, from the lowest: compounds 2 and 3 (each within the scatter of the next); then compound 1.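

In this assay the move to chloro in place of fluoro, on this aromatic carbon ortho to a large group and meta to a methanesulfonamido group, gives a 1.7-fold higher number from compound 2 to compound 3 (0.22 log units; within the scatter) and so the two substituents cannot be told apart by this read-out. Among the compounds shown here, this is the first step here between compounds that differ in one place, and it shows that this position carries either fluoro or chloro, each a single heavy atom with no hydrogen-bond donors or acceptors, without a difference beyond the scatter. Nothing on hand speaks to why the two compounds match so closely.

The compounds shown leave open whether this position stays as undemanding with anything other than these two single atoms, and a bromo, a methyl or a methoxy group there, or a plain hydrogen, would test that. They also leave open whether the same holds on other carbons of that ring, or with an acetamido group in place of the methanesulfonamido group.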